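A few compounds are considered here, and "the series" means these few. Any claim that something is new, unique, unknown or untested is made for them only; others in the source may bear on it.

In a functional assay on HepG2 cells (Homo sapiens) for inhibition, read by MTT assay (on this read-out lower numbers stand for stronger inhibition of growth and higher numbers for weaker inhibition of growth), compound 1 `COc1cc2oc(-c3cccc(NC(=O)c4ccccc4)c3)cc(=O)c2c(OC)c1OC` gives 11700 nM and compound 2 `COc1cc2oc(-c3cccc(NC(=O)c4ccc(Br)cc4)c3)cc(=O)c2c(OC)c1OC` gives 8850 nM. These two numbers lie within the usual scatter of each other, so compound 2 cannot be told apart from compound 1 on the data at hand.

Compound 3 `COc1cc2oc(-c3cccc(NC(=O)c4cccc(Br)c4)c3)cc(=O)c2c(OC)c1OC` has the same atoms as compound 2, joined differently, with 3-bromophenyl in place of 4-bromophenyl on a carbonyl carbon. Going by the values given here, no measured pair tests this exchange directly. Among the compounds with values here, the only measured step that bears on it is a 1.3-fold lower number from compound 1 to compound 2 (0.12 log units; within the scatter), for bromo in place of hydrogen on an aromatic carbon. That step concerns the presence of the bromo and not its position, so it offers only indirect guidance. On that evidence, no step beyond the scatter is expected in this assay. The expected step is a 1.0-fold higher number from compound 2 to compound 3 (0.01 log units; within the scatter). Compound 3 is estimated at 9000 nM, with an expected range from 4500 nM to 18000 nM.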

Compound 3, concentration for 50% growth inhibition: 10900 nM
Estimate against measurement, compound 3: 1.2-fold (0.08 log units) below; low and high end bracket the measured number.
By their numbers in this assay, from the lowest: compounds 2, 3 and 1 (each within the scatter of the next).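

Exchanging 4-bromophenyl for 3-bromophenyl on the carbonyl carbon gives a 1.2-fold higher number from compound 2 to compound 3 (0.09 log units; within the scatter) in this assay, the first direct test of where the bromo sits on this ring. Within this pair, the position of the bromo therefore makes no difference that can be read in this assay. Compound 3 adds a second comparison with the unsubstituted benzamide, a 1.1-fold lower number from compound 1 to compound 3 (0.03 log units; within the scatter), so that neither of the two bromo placements shown can be told apart from hydrogen, and no other information is at hand to account for these results.

The compounds shown leave open whether any group on this phenyl ring can produce a step beyond the scatter, for example an amine, a carboxylic acid or a methoxy group in place of the bromo. They also leave open what happens in this assay when the phenyl on the carbonyl carbon is itself replaced, for instance by a longer alkyl chain, since every compound here keeps that ring and the same amide-type nitrogen.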